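This account rests on a few compounds, and the source may have more. Where it says the series, first, only, none or still open, it means among the compounds named here.

The measured compounds and their values:

- compound 1, `COc1cc(OC)c(C(=O)/C=C/c2ccc([N+](=O)[O-])cc2)c(OC)c1`: 407 nM
- compound 2, `COc1cc(OC)c(C(=O)/C=C/c2cccc([N+](=O)[O-])c2)c(OC)c1`: 220 nM
- compound 3, `COc1cc(OC)c(C(=O)/C=C/c2ccc(C(=O)O)cc2)c(OC)c1`: 6230 nM

All three were tested in a functional assay for inhibition, with Homo sapiens as the target; a higher number here means a weaker inhibitor, a lower number a stronger inhibitor. Compound 1 and compound 2 are built from the same atoms joined differently; the difference between the two cores is not broken down here. In this assay compound 1 gives 407 nM and compound 2 gives 220 nM, and these two values lie within the usual scatter of each other, so nothing separates them.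

Compound 3 differs from compound 1 by a single change, (carboxy in place of nitro on an aromatic carbon). This change produced a 15-fold higher number from compound 1 to compound 3 (1.18 log units; beyond the scatter), a large step toward weaker inhibition.

Compound 4, `COc1cc(OC)c(C(=O)/C=C/c2cccc(C(=O)O)c2)c(OC)c1`, has not yet been measured. It differs from compound 2 by carboxy in place of nitro on an aromatic carbon. Within the data shown here, this is the same kind of change as the one from compound 1 to compound 3, but the setting is not identical: in compound 3 the carboxy stands para to a large group, while in compound 4 it stands meta to a large group.

Among the measured compounds shown here, since the only measured example of this change, a 15-fold higher number from compound 1 to compound 3 (1.18 log units; beyond the scatter), is far beyond the scatter, a step of similar size is expected for compound 4, namely a 15-fold higher number from compound 2 to compound 4 (1.18 log units; beyond the scatter). Compound 4 is therefore expected to give 3300 nM in this assay. The estimate for compound 4 is expected to fall between 1100 nM and 10000 nM.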

Compound 4, half-maximal inhibitory concentration: 6760 nM
Beside the measured number, compound 4's estimate is 2.0-fold (0.31 log units) below it, within the range that was stated.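

In this assay, putting carboxy in place of nitro on the second core produced a 31-fold higher number from compound 2 to compound 4 (1.49 log units; beyond the scatter), a large step toward weaker inhibition. Set beside the earlier case, the two steps cannot be told apart in size: the same change on two cores in this assay, a 15-fold higher number (1.18 log units; beyond the scatter) from compound 1 to compound 3 and a 31-fold higher number (1.49 log units; beyond the scatter) from compound 2 to compound 4, 2.0-fold (0.30 log units) apart, within the scatter of two such steps. This shows that, on the two cores available here, which differ in where the group sits on the aromatic ring, the change carried over with the same direction and a similar size, but two examples do not show that it would do so on any other core, and the numbers alone do not say why inhibition weakens.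

The compounds shown leave open whether this loss is specific to the carboxy or would also appear with other groups in the same place, such as an amine, a nitrile or a methyl ester. They also leave open whether the step would keep its size on a core changed elsewhere, for instance one with a hydroxy group in place of one of the methoxy groups.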